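Replacing the Para Ethyl Group with Nitro on Compound 3

The compounds below may be only part of what the source reports. "The series", "measured", "known", "first", "only" and "open" are said of these compounds alone.

Three amides sharing one core have been measured. Compound 1 `Cc1ccccc1C(=O)Nc1cccc(-c2oc3cc(-c4ccc(F)cc4)ccc3c(=O)c2O)c1` gives 11900 nM in a functional assay on HeLa cells (Homo sapiens) for antiproliferative activity, read by CCK-8 assay, with a stated time of 72 h; on this read-out higher numbers stand for weaker inhibition and lower numbers for stronger inhibition. Compound 2 `O=C(Nc1cccc(-c2oc3cc(-c4ccc(F)cc4)ccc3c(=O)c2O)c1)c1ccc(Br)cc1` gives 9740 nM, and compound 3 `CCc1ccc(C(=O)Nc2cccc(-c3oc4cc(-c5ccc(F)cc5)ccc4c(=O)c3O)c2)cc1` gives 21000 nM. Compound 3 shows the highest number of the three; its value and that of compound 1 lie within the scatter of each other, while a 2.2-fold higher number from compound 2 to compound 3 (0.33 log units; beyond the scatter) marks a modest step beyond it. Compound 4 `O=C(Nc1cccc(-c2oc3cc(-c4ccc(F)cc4)ccc3c(=O)c2O)c1)c1ccc([N+](=O)[O-])cc1` differs from compound 3 by nitro in place of ethyl on an aromatic carbon. For the measured compounds named here, no measured step pairs ethyl against nitro, so the bromo step is the nearest guide. Compound 4 is therefore expected to give 10000 nM (range 4000 nM to 25000 nM), which is an estimated 2.1-fold lower number from compound 3 to compound 4 (0.32 log units; beyond the scatter).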

Compound 4, half-maximal inhibitory concentration: 12300 nM
For compound 4 the middle estimate is 1.2-fold (0.09 log units) below the measured one, within the range that was stated.
By their numbers in this assay, from the lowest: compounds 2, 1, 4 and 3 (each within the scatter of the next, the first and the last beyond it).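

Nitro is the first group on this aromatic carbon to carry hydrogen-bond acceptors, yet in this assay putting it in place of ethyl stays within the scatter (a 1.7-fold lower number from compound 3 to compound 4 (0.23 log units; within the scatter)). The same holds for nitro in place of bromo (a 1.3-fold higher number from compound 2 to compound 4 (0.10 log units; within the scatter)) and for 4-nitrophenyl in place of 2-methylphenyl (a 1.0-fold higher number from compound 1 to compound 4 (0.01 log units; within the scatter)), so compound 4 cannot be told apart from any of the other three. Nothing given here offers a reason for these numbers.

Going by these compounds, whether an amine or a carboxylic acid on this carbon would give a step beyond the scatter stays open. So does whether nitro on another carbon of the same ring would give similar numbers.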